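Chloro to Trifluoromethyl on Two Spirocyclic Cores

The source may hold more compounds than are shown below. What is called first, only, known or untested is meant among the compounds shown, and "the series" means these compounds.

Measured compounds in a functional assay on CHO cells for antagonist activity at Orexin/Hypocretin receptor type 1 (Homo sapiens), read by FLIPR and calcium flux; on this read-out lower numbers stand for lower potency and higher numbers for higher potency (the scale is a negative logarithm):
compound 1 `Cc1nc(C(=O)N2CCC3(CC3)C[C@H]2CNc2ccc(C(F)(F)F)cn2)c(-c2ccccc2)s1` — compound 1 gives 7.7
compound 2 `Cc1nc(C(=O)N2CCC3(CC3)C[C@H]2CNc2ccc(Cl)cn2)c(-c2ccccc2)s1` — compound 2 gives 7.9
compound 3 `Cc1nc(C(=O)N2CC3(CC3)C[C@H]2CNc2ccc(Cl)cn2)c(-c2ccccc2)s1` — compound 3 gives 8.3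

Compound 3 stands highest of the three; the difference between its core and the core of compound 2 is not broken down here. Compounds 2 and 1 share a core and differ in one place, (trifluoromethyl in place of chloro on an aromatic carbon), which gave a number 0.20 log units lower from compound 2 to compound 1 (within the scatter). The unmeasured compound 4 `Cc1nc(C(=O)N2CC3(CC3)C[C@H]2CNc2ccc(C(F)(F)F)cn2)c(-c2ccccc2)s1` is made from compound 3 by the same change, (trifluoromethyl in place of chloro on an aromatic carbon). Since the one earlier occurrence of this change stayed within the scatter, compound 4 is expected to sit close to compound 3, with an estimated step of a number 0.20 log units lower from compound 3 to compound 4 (within the scatter). In this assay compound 4 is therefore estimated at 8.1, with a likely range from 7.7 to 8.5.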

Compound 4, negative logarithm of the antagonist equilibrium constant: 8.4
Beside the measured number, compound 4's estimate is 0.30 log units below it, and the stated range covers the measured number.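

In this assay, trifluoromethyl in place of chloro on the aromatic carbon gave a number 0.10 log units higher from compound 3 to compound 4 (within the scatter). Set beside the earlier occurrence, the step on the second core does not differ from the first: the same change on two cores in this assay, a number 0.20 log units lower (within the scatter) from compound 2 to compound 1 and a number 0.10 log units higher (within the scatter) from compound 3 to compound 4, 0.30 log units apart, within the scatter of two such steps
This shows that, on these two cores, the change carried over with no step beyond the scatter, but it does not show that the core has no influence on the change, and two pairs set no rule for other cores.

The compounds shown leave open how a nitrile, a methyl or a methoxy on that same aromatic carbon would read. They also leave open whether the change would carry over to a core other than these two.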